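A few compounds are considered here, and "the series" means these few. Any claim that something is new, unique, unknown or untested is made for them only; others in the source may bear on it.

Compound 1 `COC(CCn1cnc2c(NCc3ccc(C(=O)Nc4ccccc4N)cc3)nc(Cl)nc21)OC` was examined in a functional assay on HepG2 cells (Homo sapiens) for antiproliferative activity, read by CCK-8 assay, with a stated time of 72 h, tested at 2 uM (on this read-out higher numbers stand for a stronger effect at the one concentration tested and lower numbers for a weaker effect), and gives 8.52%. Compound 2 `Nc1ccccc1NC(=O)/C=C/c1ccc(COCNc2nc(Nc3cccc(Cl)c3)c3ncn(C4CCCC4)c3n2)cc1` gives 9.67% in this assay, so the two values lie within the usual scatter of each other and compound 1 stands alongside compound 2 rather than apart from it. Compound 3 `CC(C)n1cnc2c(NCc3ccc(C(=O)Nc4ccccc4N)cc3)nc(Cl)nc21` has not yet been measured; it differs from compound 1 by isopropyl in place of 3,3-dimethoxypropyl on an aromatic nitrogen. Going by the values given here, no measured pair shows this change, and a step within the scatter, in no particular direction, is expected because compound 1 already gives 8.52%. In this assay the expected step is a number 1.5 percentage points higher from compound 1 to compound 3 (within the scatter). Compound 3 is estimated at 10%, between 0% and 25%.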

Compound 3, a percentage reported as inhibition, at one concentration (the size of the read-out at that concentration, not a potency): 63.8%
Beside the measured number, compound 3's estimate is 53.8 percentage points below it; the measured number lies above the stated range.
By their numbers in this assay, from the lowest: compounds 1 and 2 (each within the scatter of the next); then compound 3.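

In this assay, the group on this aromatic nitrogen of the shared core matters greatly: isopropyl in place of 3,3-dimethoxypropyl gives a number 55.3 percentage points higher from compound 1 to compound 3 (beyond the scatter) at this single concentration. Going by these compounds alone, this is the first measured pair to change this position, and it shows that one change here alone can separate two compounds well beyond the scatter. No measurement at hand explains the step.
Open, from the compounds shown here alone, is whether the chain's length or its two oxygens go with the lower number, which a plain butyl chain could separate. Also open, going by these compounds, is how methyl or a 2-aminoethyl chain would compare with isopropyl here.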